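From phenyl to thiophen-2-yl in compound 3

The source may report more compounds than this note shows. Statements on the series, on what has been measured and on what is new or still open speak of the compounds shown alone.

Compound 1 `Oc1ccccc1-c1cc(-c2ccccc2)cc(-c2ccccc2O)n1` gives 37300 nM
Compound 2 `Oc1cccc(-c2cc(-c3ccccc3)cc(-c3ccccc3)n2)c1` gives 19300 nM

Both numbers come from a functional assay on MDA-MB-231 cells (Homo sapiens) for cytotoxicity, read by ELISA, with a stated time of 2 days (a lower number here means a stronger inhibitor, a higher number a weaker inhibitor), and they lie within the usual scatter of each other. Compound 2 therefore stands level with compound 1, and neither can be ranked above the other. Among the measured compounds shown here, the two also differ in more than one place, so they offer no single-change step to learn from.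

Compound 3 (`Oc1cccc(-c2cc(-c3ccccc3)cc(-c3cccs3)n2)c1`) keeps the rest of compound 2 but carries thiophen-2-yl in place of phenyl on an aromatic carbon, next to the ring nitrogen (thiophen-2-yl in place of phenyl on an aromatic carbon). With no measured single change as a guide, only a small effect is expected in this assay, with a slight lean toward a lower number. The estimated 1.2-fold lower number from compound 2 to compound 3 (0.08 log units; within the scatter) stays within the scatter. For compound 3 the expected value is 16000 nM (estimated range 6000 nM to 40000 nM).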

Compound 3, half-maximal inhibitory concentration: 18100 nM
The estimate for compound 3 lay 1.1-fold (0.05 log units) below the measured number; low and high end bracket the measured number.
By their numbers in this assay, from the lowest: compounds 3, 2 and 1 (each within the scatter of the next, the first and the last beyond it).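

Among the compounds shown here, the first single change that can be read gives a 1.1-fold lower number from compound 2 to compound 3 (0.03 log units; within the scatter) in this position next to the ring nitrogen. In this assay the five-membered thiophen-2-yl ring, with its sulfur atom, therefore reads level with the six-membered phenyl ring it replaces, so this one swap of aromatic rings gives no sign of either a gain or a loss. Nothing measured here explains why the two groups read alike.

The compounds shown leave open whether a group of a different kind at this position, such as an amine, a carboxylic acid or a longer alkyl chain, would shift the number beyond the scatter. They also leave open whether thiophen-2-yl would read the same in place of the remaining phenyl group.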